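Swapping the Chalcone Aryl: Chlorine Out, Two Fluorines In

This account rests on a few compounds, and the source may have more. Where it says the series, first, only, none or still open, it means among the compounds named here.

compound 1 `O=C(COc1ccc(C(=O)/C=C/c2ccccc2Cl)cc1)N[C@H]1CCOC1=O` — 3240 nM
compound 2 `O=C1OCC[C@@H]1NC(=S)SCCOc1ccccc1[N+](=O)[O-]` — 33400 nM
compound 3 `O=C1OCC[C@@H]1NC(=S)SCCOc1ccc(Cl)cc1` — > 64000 nM (a limit, not a number)

In a functional assay on DU-145 cells (Homo sapiens) for antiproliferative activity, read by MTT assay, with a stated time of 72 h (a higher number here means a weaker inhibitor, a lower number a stronger inhibitor), compound 1 gives 3240 nM, the lowest of the two numbers shown. Compound 2 gives 33400 nM, a higher number, beyond the scatter. For compound 3 the result is only a limit, > 64000 nM, as described by the limit of > 64000 nM in this assay, at which 1 of the 3 values shown sits.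

Compound 4 `O=C(COc1ccc(C(=O)/C=C/c2ccc(F)c(F)c2)cc1)N[C@H]1CCOC1=O` has not yet been measured in this assay. It differs from compound 1 by 3,4-difluorophenyl in place of 2-chlorophenyl on a double-bonded chain carbon bound to a double-bonded chain carbon. Within the data shown here, no measured step between such aryl groups is available here, so the expected step is none beyond the scatter, in either direction. Compound 4 is therefore expected to give about 3500 nM, within 1200 nM to 10000 nM, an expected step of a 1.1-fold higher number from compound 1 to compound 4 (0.03 log units; within the scatter).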

Compound 4, half-maximal inhibitory concentration: 19800 nM
The estimate for compound 4 lay 5.7-fold (0.75 log units) below the measured number; the measured number lies above the stated range.
By their numbers in this assay, from the lowest: compound 1; then compounds 4 and 2 (each within the scatter of the next). At a limit, above all of these: compound 3.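

The first pair shown that differs in one place makes this position readable in this assay: 3,4-difluorophenyl in place of 2-chlorophenyl gives a 6.1-fold higher number from compound 1 to compound 4 (0.79 log units; beyond the scatter). The position therefore responds to the choice of aryl group, although each group is a six-membered aromatic ring of carbon only with no net charge. Nothing measured among these compounds gives a cause for this step.

From the compounds shown here alone, it remains open whether the chlorine's leaving or the fluorines' entering drives the step. Also open, going by these compounds, is how a plain phenyl or a pyridine ring would read at this place.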